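Cytotoxicity notes on the chalcone amide series

The source may report more compounds than this note shows. Statements on the series, on what has been measured and on what is new or still open speak of the compounds shown alone.

Compound 1 `COC(=O)c1cc(-c2cccc(NC(=O)c3ccc(/C=C/C(=O)c4ccccc4)cc3)c2)on1` in an ADME assay on Vero cells (Chlorocebus sabaeus) for cytotoxicity, read by MTT assay, with a stated time of 72 h (a higher number here means that more compound is tolerated, a lower number that less compound is tolerated), reaches only the assay limit > 50 ug/mL. Compound 2 `COC(=O)c1cc(-c2cccc(NC(=O)c3ccc(/C=C/C(=O)c4cccc(C(F)(F)F)c4)cc3)c2)on1` in this assay likewise stops at a limit, > 20 ug/mL. Compound 3 `COC(=O)c1cc(-c2cccc(NC(=O)c3ccc(/C=C/C(=O)c4cccc(Cl)c4)cc3)c2)on1` in this assay is known only to a limit, > 2.5 ug/mL. The steps a step that the two limits leave unreadable from compound 1 to compound 2, a step that the two limits leave unreadable from compound 1 to compound 3 and a step that the two limits leave unreadable from compound 2 to compound 3 are therefore unreadable, and the limits (the limit of > 2.5 ug/mL in this assay, at which 1 of the 3 values shown sits), the limit of > 20 ug/mL in this assay, at which 1 of the 3 values shown sits, and the limit of > 50 ug/mL in this assay, at which 1 of the 3 values shown sits, give no number for any of the three. Compound 4 `COC(=O)c1cc(-c2cccc(NC(=O)c3ccc(/C=C/C(=O)c4ccccc4Cl)cc3)c2)on1` differs from compound 3 by 2-chlorophenyl in place of 3-chlorophenyl on a carbonyl carbon. For the measured compounds named here, no measured step bears on this change, so no shift beyond the scatter is expected, and a step that the limit leaves unreadable from compound 3 to compound 4 is expected to be small. Compound 4 is expected at 20 ug/mL, between 5 ug/mL and 50 ug/mL, most likely again reported as a limit.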

Compound 4, half-maximal cytotoxic concentration: > 25 ug/mL
Compound 4 ended at the assay's limit; the forecaster's own chance of this, stated with the estimate: 80%; at least 1.2-fold (0.09 log units) between middle value and limit.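

Compound 4 also stops at a limit, so its steps from compound 1, compound 2 and compound 3 cannot be read. The compounds shown leave open whether 2-chlorophenyl and 3-chlorophenyl differ at all in this assay.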